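The compounds below may be only part of what the source reports. "The series", "measured", "known", "first", "only" and "open" are said of these compounds alone.

Measured in an ADME assay on L929 cells (Mus musculus) for cytotoxicity, read by resazurin assay, with a stated time of 48 h; on this read-out higher numbers stand for lower toxicity in this test and lower numbers for higher toxicity in this test:
Compound 1 `O=c1c2cc([N+](=O)[O-])ccc2n(CCCBr)n1Cc1ccccc1`: 25200 nM
Compound 2 `O=c1c2cc([N+](=O)[O-])ccc2n(CCO)n1Cc1ccccc1`: > 256000 nM

For compound 2, > 256000 nM is a limit of the assay and not a number. It sits at the low-toxicity end of the two results. Compound 3 `CCOCCCn1c2ccc([N+](=O)[O-])cc2c(=O)n1Cc1ccccc1` carries ethoxymethyl in place of hydroxy on a saturated chain carbon, two bonds along the chain from an aromatic nitrogen.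

Within the data shown here, one measured step concerns this same place: an at least 10-fold higher number from compound 1 to compound 2 (1.00 log units; beyond the scatter). That step is beyond the scatter, but it involves bromomethyl rather than ethoxymethyl, so it is only a loose guide. Compound 3 gives up the hydroxy, as compound 1 lacks it, so a move to a lower number in this assay is expected, though a smaller one than that step. The expected change is an at least 1.9-fold lower number from compound 2 to compound 3 (0.29 log units; that floor lies within the scatter). Compound 3 is expected at 130000 nM, with an estimated range from 45000 nM to 256000 nM.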

Compound 3, concentration lethal to 50% of the cells: 170000 nM
Estimate against measurement, compound 3: 1.3-fold (0.12 log units) below, and the stated range covers the measured number.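

In this assay, ethoxy in place of bromo gives a 6.7-fold higher number from compound 1 to compound 3 (0.83 log units; beyond the scatter), so a hydroxy at the chain end is not needed to move well away from compound 1: the ethoxymethyl group has no hydrogen-bond donor, and the number still rises beyond the scatter. Ethoxymethyl in place of hydroxy gives an at least 1.5-fold lower number from compound 2 to compound 3 (0.17 log units; that floor lies within the scatter), and since that floor lies within the scatter, this swap shows no firm rise in toxicity. Compound 2 stands at a limit of the assay and not at a number, so the true size of that step stays open: the limit of > 256000 nM in this assay, at which 1 of the 3 values shown sits.

As far as these compounds go, whether an amine or a carboxylic acid at this place would read like compound 3 remains open. So does how a longer chain ending in ethoxy would read in this assay.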